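Sulfur-linked side chain: aryl versus ester groups

The source may hold more compounds than are shown below. What is called first, only, known or untested is meant among the compounds shown, and "the series" means these compounds.

Three compounds share one core; compound 1 `O=C(O)Cn1c(SCCCc2ccccc2)nc2ccccc21` carries a phenylpropyl chain on the sulfur, compound 2 `O=C(O)Cn1c(SCCNc2ccccc2)nc2ccccc21` an anilino-ethyl chain, compound 3 `CCOC(=O)CCSc1nc2ccccc2n1CC(=O)O` an ethoxycarbonyl-ethyl chain. In an assay on HEK293 cells for displacement of a labelled ligand from prostaglandin D2 receptor 2 (Homo sapiens) (a higher number here means a weaker inhibitor, a lower number a stronger inhibitor), compound 1 gives 475 nM, compound 2 gives 7690 nM and compound 3 gives 11400 nM. Compound 3 has the highest number of the three; the step of a 1.5-fold higher number from compound 2 to compound 3 (0.17 log units; within the scatter) is within the scatter, so compound 2 and compound 3 are not separated, while a 16-fold higher number from compound 1 to compound 2 (1.21 log units; beyond the scatter) and a 24-fold higher number from compound 1 to compound 3 (1.38 log units; beyond the scatter) are both large.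

Compound 4 `O=C(O)Cn1c(SCc2ccccc2Cl)nc2ccccc21` is the untested member. It differs from compound 3 by 2-chlorophenyl in place of (ethoxycarbonyl)methyl on a saturated chain carbon bound to a sulfur. Going by the values given here, the only step that bears on this change is a 24-fold higher number from compound 1 to compound 3 (1.38 log units; beyond the scatter), where an aromatic ring on the chain was exchanged for the ester and the number rose markedly. Compound 4 restores an aromatic ring, though on a shorter chain and bearing a chlorine, so the reverse direction is expected but with less confidence in its full size. The step of a 7.6-fold lower number from compound 3 to compound 4 (0.88 log units; beyond the scatter) is therefore expected to be downward, beyond the scatter. For compound 4 an estimate of 1500 nM in this assay is made, with a range from 350 nM to 6500 nM.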

Compound 4, half-maximal inhibitory concentration: 370 nM
Compound 4: middle estimate off by 4.1-fold (0.61 log units), on the high side; low and high end bracket the measured number.
By their numbers in this assay, from the lowest: compounds 4 and 1 (each within the scatter of the next); then compounds 2 and 3 (each within the scatter of the next).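

At the saturated chain carbon bound to a sulfur, 2-chlorophenyl in place of (ethoxycarbonyl)methyl gives, in this assay, a 31-fold lower number from compound 3 to compound 4 (1.49 log units; beyond the scatter), so a large drop in the number does not depend on the longer phenylpropyl chain of compound 1. Compound 4 at 370 nM and compound 1 at 475 nM lie within the scatter of each other, which leaves the shorter chlorine-bearing side chain and the longer unsubstituted one not separated in this assay. Compound 2 also carries an aromatic ring on its chain and gives 7690 nM, so the presence of an aromatic ring does not by itself set the number, and nothing measured here explains these differences.

Compound 4 differs from compound 1 in both chain length and the chlorine, so the compounds shown do not tell how much each of these contributes to its number. Also open, on these data alone, is whether a bromine, a methyl or a methoxy group in place of the chlorine would keep the number in the range of compound 4.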